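Swapping furan-3-yl for thiophen-3-yl on a carbonyl carbon

The source may hold more compounds than are shown below. What is called first, only, known or untested is meant among the compounds shown, and "the series" means these compounds.

- compound 1 `CCCCCCCCCCCC[C@@H](O)[C@H]1CC[C@H]([C@H](O)CCCCCCCCCCNC(=O)c2cccs2)O1`: 676 nM
- compound 2 `CCCCCCCCCCCC[C@@H](O)[C@H]1CC[C@H]([C@H](O)CCCCCCCCCCNC(=O)c2ccoc2)O1`: 3020 nM
- compound 3 `CCCCCCCCCCCC[C@@H](O)[C@H]1CC[C@H]([C@H](O)CCCCCCCCCCNC(=O)c2cncs2)O1`: 4790 nM

These three compounds share one core and differ only in the ring on the carbonyl carbon. All were tested in a functional assay on NCI-H23 cells (Homo sapiens) for inhibition, read by colorimetric assay and sulforhodamine B assay, with a stated time of 48 h; a higher number here means a weaker inhibitor of growth, a lower number a stronger inhibitor of growth. Compound 2 gives 3020 nM there. The gap of a 1.6-fold higher number from compound 2 to compound 3 (0.20 log units; within the scatter) lies within the scatter, so those two values cannot be told apart. By contrast, a 4.5-fold higher number from compound 1 to compound 2 (0.65 log units; beyond the scatter) lies beyond the scatter.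

Compound 4 `CCCCCCCCCCCC[C@@H](O)[C@H]1CC[C@H]([C@H](O)CCCCCCCCCCNC(=O)c2ccsc2)O1` is not yet measured. It differs from compound 2 in one group: thiophen-3-yl in place of furan-3-yl on a carbonyl carbon. The closest evidence is that same step, a 4.5-fold higher number from compound 1 to compound 2 (0.65 log units; beyond the scatter), where furan-3-yl replaced thiophen-2-yl. Read backwards, it suggests that a thiophen-3-yl group may bring the number down. However, thiophen-3-yl is not thiophen-2-yl, and no measurement here separates the two, so only part of that gap is expected to return. The expected change is a 2.3-fold lower number from compound 2 to compound 4 (0.37 log units; beyond the scatter). For compound 4 the estimated value is 1300 nM, with an expected range of 500 nM to 3500 nM.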

Compound 4, concentration for 50% growth inhibition: 200 nM
Compound 4: middle estimate off by 6.5-fold (0.81 log units), on the high side; the measured number lies below the stated range.
By their numbers in this assay, from the lowest: compound 4; then compound 1; then compounds 2 and 3 (each within the scatter of the next).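

In this assay the swap of furan-3-yl for thiophen-3-yl on a carbonyl carbon gives a 15-fold lower number from compound 2 to compound 4 (1.18 log units; beyond the scatter) even though the two rings have the same size and the same counted donors and acceptors, so exchanging one ring oxygen for sulfur can matter greatly here. Sulfur alone does not account for the pattern, since thiophen-3-yl also gives a 24-fold lower number from compound 3 to compound 4 (1.38 log units; beyond the scatter) when it replaces 1,3-thiazol-5-yl, which contains sulfur as well. The two thiophene groups are not interchangeable either, with a 3.4-fold lower number from compound 1 to compound 4 (0.53 log units; beyond the scatter) and compound 4 the most potent of the four.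

From the compounds shown here alone, whether a phenyl or cyclohexyl group on the carbonyl carbon, or a methyl or chloro group on thiophen-3-yl, would keep this potency remains open. Nothing shown here gives a reason for these differences.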